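Amide substituent variation on the shared core

The source may report more compounds than this note shows. Statements on the series, on what has been measured and on what is new or still open speak of the compounds shown alone.

In an assay on cells for positive allosteric modulation of Cystic fibrosis transmembrane conductance regulator variant F508del (Homo sapiens), with stated times of 10 min and 7 s, in the presence of a further agent that is not named here (on this read-out higher numbers stand for an effect only at larger amounts of compound and lower numbers for an effect already at smaller amounts), compound 2 `CC1(C)Cc2c(sc(NC(=O)c3ccn[nH]3)c2C(N)=O)C(C)(C)O1` gives 3 nM. Compound 1 `CC1(C)Cc2c(sc(NC(=O)c3ccccc3O)c2C(N)=O)C(C)(C)O1` gives 4 nM; on the numbers shown compound 2 holds the lowest value, yet the step of a 1.3-fold lower number from compound 1 to compound 2 (0.12 log units; within the scatter) lies within the scatter, so the two are not distinguishable. Compound 3 `CC1(C)Cc2c(sc(NC(=O)C3(O)CC3)c2C(N)=O)C(C)(C)O1` carries 1-hydroxycyclopropyl in place of 1H-pyrazol-5-yl on a carbonyl carbon. Going by the values given here, the only measured step swaps one ring for another on the same carbonyl carbon and barely moves the number; no measured step removes the aromatic ring, so the size of this change is uncertain. For compound 3 a moderately higher number is expected, a 2.7-fold higher number from compound 2 to compound 3 (0.43 log units; beyond the scatter), giving an estimate of 8 nM within 2 nM to 40 nM.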

Compound 3, half-maximal effective concentration: 23 nM
Beside the measured number, compound 3's estimate is 2.9-fold (0.46 log units) below it; low and high end bracket the measured number.
By their numbers in this assay, from the lowest: compounds 2 and 1 (each within the scatter of the next); then compound 3.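

Putting 1-hydroxycyclopropyl on the carbonyl carbon in this assay gives a step beyond the scatter from either aromatic group (a 7.7-fold higher number from compound 2 to compound 3 (0.88 log units; beyond the scatter); a 5.8-fold higher number from compound 1 to compound 3 (0.76 log units; beyond the scatter)). The earlier exchange of 2-hydroxyphenyl for 1H-pyrazol-5-yl stayed within the scatter, so this position tolerates that aromatic exchange but not this non-aromatic replacement equally. Nothing measured here explains the loss.

From the compounds shown here alone, whether the step follows from losing the aromatic ring or from the three-membered ring itself remains open. Plain cyclopropyl or 1-aminocyclopropyl on the same carbonyl carbon would bear on that.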